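The source may report more compounds than this note shows. Statements on the series, on what has been measured and on what is new or still open speak of the compounds shown alone.

Measured compounds:
compound 1 `CCCCCCc1cc2cn(Cc3cn(-c4ccccc4F)nn3)c(=O)nc2o1`; compound 2 `CCCCCCC#Cc1c(CCCCCC)oc2nc(=O)n(Cc3cn(-c4ccc(Cl)cc4)nn3)cc12`; compound 3 `CCCCCCC#Cc1c(CCCCCC)oc2nc(=O)n(Cc3cn(Cc4ccccc4)nn3)cc12`

In a functional assay on CFPAC-1 cells (Homo sapiens) for antiproliferative activity, read by MTT assay, with a stated time of 72 h (a higher number here means a weaker inhibitor, a lower number a stronger inhibitor), compound 1 reaches only the limit > 100000 nM. In this assay compound 2 likewise reaches only the limit > 100000 nM. For the measured compounds named here, compound 3 is the single compound of the three with an actual number: in this assay compound 3 gives 27300 nM. Compound 3 is therefore the only point on which a number, not a limit, can be built.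

Going by the values given here, the one measured step with a single change is an at least 3.6-fold lower number from compound 2 to compound 3 (0.56 log units; beyond the scatter), which moves off the limit onto a number. Compound 1 and compound 2 both sit at the limit (the limit of > 100000 nM in this assay, at which 2 of the 3 values shown sit) and differ in two places at once, so nothing is said about them as a pair beyond that.

Compound 4 is `CCCCCCc1cc2cn(Cc3cn(Cc4ccccc4)nn3)c(=O)nc2o1`. It differs from compound 3 in this way: hydrogen in place of oct-1-yn-1-yl on an aromatic carbon. Among the compounds with values here, no measured step here isolates this change; compound 1, which also lacks the oct-1-yn-1-yl group, sits at the limit, but it carries a different group on the triazole nitrogen too. Compound 4 is expected to weaken, with an estimated step of a 2.9-fold higher number from compound 3 to compound 4 (0.47 log units; beyond the scatter). For compound 4 in this assay the estimate is 80000 nM, within 25000 nM to 300000 nM, with a real chance that only a limit is returned.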

Compound 4, half-maximal inhibitory concentration: 67000 nM
Estimate against measurement, compound 4: 1.2-fold (0.08 log units) above; the range from low to high includes it.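

Hydrogen in place of oct-1-yn-1-yl, on the aromatic carbon next to the ring atom that bears a hexyl group, gives a 2.5-fold higher number from compound 3 to compound 4 (0.39 log units; beyond the scatter) in this assay. For the compounds shown here, this is the first single-change reading at this position, and it shows a modest weakening: the oct-1-yn-1-yl group is not needed for a measurable value, since compound 4 still returns a number and not a limit. Benzyl in place of 2-fluorophenyl gives an at least 1.4-fold lower number from compound 1 to compound 4 (0.17 log units; that floor lies within the scatter), so this pair fixes no size for the change, although among these four compounds only the two benzyl compounds, compound 3 and compound 4, return numbers, while the 2-fluorophenyl and 4-chlorophenyl compounds, compound 1 and compound 2, stay at a limit: the limit of > 100000 nM in this assay, at which 2 of the 4 values shown sit.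

The compounds shown leave open whether the step at this position follows the chain or the triple bond, which a saturated octyl group or a shorter alkynyl group there would separate. Also open, on these data alone, is how far the benzyl reading extends, for example to a phenethyl group or to a benzyl ring carrying an amine.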